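A Dimethylphenyl Analogue of Compound 2

The source may hold more compounds than are shown below. What is called first, only, known or untested is meant among the compounds shown, and "the series" means these compounds.

Three compounds in this series have measured values. Compound 2 `COC(=O)/C=C/c1ccc2c(c1)C(=O)C(=O)N2Cc1ccc(Cl)c(Cl)c1` gives 160 nM in a functional assay on HepG2 cells (Homo sapiens) for cytotoxicity, read by MTT assay, with a stated time of 48 h (a higher number here means a weaker inhibitor, a lower number a stronger inhibitor), the lowest of the two numbers reported. Compound 1 `COc1ccc(CN2C(=O)C(=O)c3cc(/C=C/C(=O)OCCO)ccc32)cc1` gives 860 nM in this assay, a gap from compound 2 that lies beyond the scatter. Compound 3 `CCCCc1ccc2c(c1)C(=O)C(=O)N2` reaches only a limit in this assay, > 10000 nM, so it stands as a limit and not as a number (the limit of > 10000 nM in this assay, at which 1 of the 3 values shown sits).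

The next compound, compound 4 `COC(=O)/C=C/c1ccc2c(c1)C(=O)C(=O)N2Cc1cc(C)cc(C)c1`, differs from compound 2 in one place: 3,5-dimethylphenyl in place of 3,4-dichlorophenyl on a saturated chain carbon bound to an amide-type nitrogen in a ring. No pair of measured compounds isolates this change, so its effect cannot be read from the data shown. In this assay a modest step is expected from this replacement, more likely toward a higher number than a lower one, though it may well fall within the scatter. The step from compound 2 to compound 4 is estimated as a 2.2-fold higher number from compound 2 to compound 4 (0.34 log units; beyond the scatter). Compound 4 is therefore expected to give about 350 nM, within a range from 120 nM to 1200 nM.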

Compound 4, half-maximal inhibitory concentration: 150 nM
The estimate for compound 4 lay 2.3-fold (0.37 log units) above the measured number; the range from low to high includes it.
By their numbers in this assay, from the lowest: compounds 4 and 2 (each within the scatter of the next); then compound 1. At a limit, above all of these: compound 3.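

The exchange of 3,4-dichlorophenyl for 3,5-dimethylphenyl on a saturated chain carbon bound to an amide-type nitrogen in a ring gives a 1.1-fold lower number from compound 2 to compound 4 (0.03 log units; within the scatter) in this assay. This is the only pair shown that differs in one place, and it indicates that, at this position, two methyl groups on the aromatic ring can stand in for two chlorine atoms with no change beyond the scatter. Nothing measured among the compounds shown accounts for this result.

From the compounds shown here alone, whether an amine or a carboxylic acid on this aromatic ring would leave the number equally undisturbed remains open. Compounds 1 and 3 each differ from the others in more than one place, so the steps that involve them cannot be read.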